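Octylsulfanyl analogue of compound 1: cytotoxicity outlook

A few compounds are considered here, and "the series" means these few. Any claim that something is new, unique, unknown or untested is made for them only; others in the source may bear on it.

Measured so far:
compound 1 `CC(C)CSc1nc(N)nc2c1ncn2/C=C1/CC1(CO)CO` — > 20000 nM
compound 2 `Nc1nc(NCc2ccccc2)c2ncn(/C=C3/CC3(CO)CO)c2n1` — > 24000 nM
compound 3 `CCCNc1nc(N)nc2c1ncn2/C=C1/CC1(CO)CO` — > 24000 nM

In an ADME assay on Akata cells (Homo sapiens) for cytotoxicity, with a stated time of 7 days (on this read-out higher numbers stand for lower toxicity in this test and lower numbers for higher toxicity in this test), compound 1 returns only a limit, > 20000 nM. Compound 2 likewise sits at a limit, > 24000 nM. Compound 3 also gives a limit, > 24000 nM. Every measured step therefore stays unreadable: a step that the two limits leave unreadable from compound 1 to compound 2, a step that the two limits leave unreadable from compound 1 to compound 3 and a step that the two limits leave unreadable from compound 2 to compound 3. The unmeasured compound 4 `CCCCCCCCSc1nc(N)nc2c1ncn2/C=C1/CC1(CO)CO` differs from compound 1 by heptyl in place of isopropyl on a saturated chain carbon bound to a sulfur. Within the data shown here, none of the measured steps touches the sulfanyl chain, and no direction can be read from them; the limit of > 20000 nM in this assay, at which 1 of the 3 values shown sits, and the limit of > 24000 nM in this assay, at which 2 of the 3 values shown sit, show only where the series has stood so far. The step of an at least 1.1-fold lower number from compound 1 to compound 4 (0.04 log units; that floor lies within the scatter) is thus an expectation with little support. Compound 4 is estimated at 18000 nM, range 5000 nM to 40000 nM, with a fair chance that only a limit is again reported.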

Compound 4, half-maximal cytotoxic concentration: > 20000 nM
Compound 4 ended at the assay's limit; the forecaster's own chance of this, stated with the estimate: 55%; at least 1.1-fold (0.04 log units) between middle value and limit.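

Compound 4, like compound 1, compound 2 and compound 3, returns only a limit, and its steps to those three compounds cannot be read. The compounds shown leave open whether any of these chains on the shared core gives a measurable cytotoxic concentration.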